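The source may hold more compounds than are shown below. What is called first, only, known or untested is meant among the compounds shown, and "the series" means these compounds.

Measured compounds:
- Compound 1 `N#Cc1ccc(Nc2nc(Oc3ccnc4ccccc34)nc(N3CCN(C(c4ccccc4)c4ccc(Cl)cc4)CC3)n2)cc1C(F)(F)F`, in a functional assay on DU-145 cells (Homo sapiens) for cytotoxicity, read by sulforhodamine B assay, with a stated time of 48 h (a higher number here means a weaker inhibitor of growth, a lower number a stronger inhibitor of growth), compound 1 gives > 100000 nM, which is a limit of the assay
- Compound 2 `N#Cc1ccc(Nc2nc(Oc3ccnc4ccccc34)nc(N3CCN(c4cccc(C(F)(F)F)c4)CC3)n2)cc1C(F)(F)F`, in this assay compound 2 gives 74100 nM

Compound 1 reaches only a limit in this assay and gives no number (the limit of > 100000 nM in this assay, at which 1 of the 2 values shown sits). Within the data shown here, compound 2 therefore stands as the only compound with a number in this assay; the one other value is a limit, so no ordering between the two can be drawn beyond what the limit allows.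

Compound 3 `N#Cc1ccc(Nc2nc(Oc3ccnc4ccccc34)nc(N3CCN(c4ccccc4)CC3)n2)cc1C(F)(F)F` is the next compound, not yet measured in this assay. It differs from compound 2 in one place: hydrogen in place of trifluoromethyl on an aromatic carbon. Among the measured compounds shown here, no measured pair of compounds shows this change, so its size in this assay has to be estimated. The expectation is a step from compound 2 to compound 3 of about a 1.2-fold higher number from compound 2 to compound 3 (0.08 log units; within the scatter), that is, no change beyond the usual scatter or a slight drift toward weaker growth inhibition, with a real chance that only a limit is reported. For compound 3 the estimated value in this assay is 90000 nM, with a range from 40000 nM to 200000 nM.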

Compound 3, concentration for total growth inhibition: > 100000 nM
Compound 3: only a limit was reported; the forecaster's own chance of this, stated with the estimate: 45%; at least 1.1-fold (0.04 log units) between middle value and limit.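

Compound 3 gives > 100000 nM in this assay, and this value is a limit of the assay, not a number. As far as these compounds go, the change from 3-(trifluoromethyl)phenyl to phenyl, on an aromatic carbon of the ring that carries it, amounts to an at least 1.3-fold higher number from compound 2 to compound 3 (0.13 log units; that floor lies within the scatter); this is only a floor, so the real size of the step stays unknown and it cannot be said whether the trifluoromethyl matters here. The earlier compounds offered no pair differing in one place, so this is the first reading at this position, and it leaves the only number in the set resting on a single compound: the limit of > 100000 nM in this assay, at which 2 of the 3 values shown sit.

From the compounds shown here alone, whether another group at this place on the phenyl, such as a methoxy, a chlorine atom or an amine, would give a number rather than a limit in this assay stays open. Also open, going by these compounds, is how the step would read if the comparison were made in a compound whose values both lay within the measurable range, since a floor within the scatter cannot settle its size.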